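Dimethylamino at the amine position of a triazolopyrimidine ester

A few compounds are considered here, and "the series" means these few. Any claim that something is new, unique, unknown or untested is made for them only; others in the source may bear on it.

Measured so far:
compound 1 `CCOC(=O)c1cnc(NC2CC2)n2nc(-c3ccco3)nc12` gives 60.7 nM
compound 2 `CCOC(=O)c1cnc(NC2CCCC2)n2nc(-c3ccco3)nc12` gives 34.4 nM
compound 3 `CCOC(=O)c1cnc(NCc2ccc(F)cc2)n2nc(-c3ccco3)nc12` gives 932 nM

These values come from an assay on CHO cells for displacement of a labelled ligand from adenosine receptor A1 (Homo sapiens); on this read-out lower numbers stand for stronger inhibition and higher numbers for weaker inhibition. Compound 3 has the highest number of the three. The measured steps that bear on the next change both end at compound 3: a 15-fold higher number from compound 1 to compound 3 (1.19 log units; beyond the scatter) and a 27-fold higher number from compound 2 to compound 3 (1.43 log units; beyond the scatter), each a large rise when a small cycloalkyl group gave way to the 4-fluorobenzyl group. Compound 4 `CCOC(=O)c1cnc(N(C)C)n2nc(-c3ccco3)nc12` makes a new change, (dimethylamino in place of (4-fluorobenzyl)amino on an aromatic carbon). The group entering is small, like those of compound 1 and compound 2, so the number for compound 4 is expected to fall, a 3.7-fold lower number from compound 3 to compound 4 (0.57 log units; beyond the scatter), though not fully back. The estimate for compound 4 is 250 nM, with a range from 50 nM to 1500 nM.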

Compound 4, inhibition constant: 13400 nM
Beside the measured number, compound 4's estimate is 54-fold (1.73 log units) below it, and the stated range ends below it.
By their numbers in this assay, from the lowest: compounds 2 and 1 (each within the scatter of the next); then compound 3; then compound 4.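

In this assay, a small group alone does not restore the number: the change gives a 220-fold higher number from compound 1 to compound 4 (2.34 log units; beyond the scatter) and a 390-fold higher number from compound 2 to compound 4 (2.59 log units; beyond the scatter), and it even gives a 14-fold higher number from compound 3 to compound 4 (1.16 log units; beyond the scatter). Among these compounds, only compound 4 has two carbon groups and no hydrogen on this nitrogen, so the loss of that hydrogen and the change in group cannot be separated here. Nothing available explains the drop. Methylamino, which keeps that hydrogen and adds one methyl, would help separate them, and pyrrolidine would test a ring with no such hydrogen.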